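The compounds below may be only part of what the source reports. "The series", "measured", "known", "first", "only" and "open" are said of these compounds alone.

For the measured compounds named here, compound 2, `CCCCc1nc(CN2CCN(c3cccc4[nH]c(-c5ccc(C(C)(C)C)cc5)nc34)CC2)cn1C`, gives 26 nM in an assay on isolated protein for displacement of a labelled ligand from Gonadotropin-releasing hormone receptor (Homo sapiens) (on this read-out higher numbers stand for weaker inhibition and lower numbers for stronger inhibition), the lower of the two numbers measured so far. Going by the values given here, its only measured neighbour is compound 1, `Cc1n[nH]c(C)c1CN1CCN(c2cccc3[nH]c(-c4ccc(C(C)(C)C)cc4)nc23)CC1`, which in this assay gives 68 nM. Among the compounds with values here, the one step between them, a 2.6-fold lower number from compound 1 to compound 2 (0.42 log units; beyond the scatter), is the only measured step that bears on the question ahead, and it came from exchanging one five-membered aromatic ring with 2 hetero atoms for another on the saturated chain carbon bound to the amine nitrogen in the ring.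

Compound 3, `CCCn1c(CC)nc(C)c1CN1CCN(c2cccc3[nH]c(-c4ccc(C(C)(C)C)cc4)nc23)CC1`, has not been measured. It differs from compound 2 in one place: 2-ethyl-4-methyl-1-propyl-1H-imidazol-5-yl in place of 2-butyl-1-methyl-1H-imidazol-4-yl on a saturated chain carbon bound to an amine nitrogen in a ring. Both the group that leaves and the group that enters are five-membered aromatic rings with 2 hetero atoms, without hydrogen-bond donors and with 2 hydrogen-bond acceptors each; what changes is the set of alkyl chains on that ring and the point at which it is attached. Within the data shown here, since the one comparable step, from compound 1 to compound 2, was only modest, compound 3 is expected to stay close to compound 2, with a step of a 1.2-fold higher number from compound 2 to compound 3 (0.06 log units; within the scatter) that may well lie within the scatter. The estimate for compound 3 in this assay is 30 nM, ranging from 12 nM to 80 nM.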

Compound 3, half-maximal inhibitory concentration: 57 nM
Estimate against measurement, compound 3: 1.9-fold (0.28 log units) below; measured number inside the range.
By their numbers in this assay, from the lowest: compound 2; then compounds 3 and 1 (each within the scatter of the next).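

On a saturated chain carbon bound to an amine nitrogen in a ring, replacing 2-butyl-1-methyl-1H-imidazol-4-yl with 2-ethyl-4-methyl-1-propyl-1H-imidazol-5-yl gives a 2.2-fold higher number from compound 2 to compound 3 (0.34 log units; beyond the scatter) in this assay and shows that two groups with the same type of ring and the same hydrogen-bond donor and acceptor counts are not interchangeable here. The advantage of 2-butyl-1-methyl-1H-imidazol-4-yl over 3,5-dimethyl-1H-pyrazol-4-yl does not extend to the other alkylated group, as replacing 3,5-dimethyl-1H-pyrazol-4-yl with 2-ethyl-4-methyl-1-propyl-1H-imidazol-5-yl gives a 1.2-fold lower number from compound 1 to compound 3 (0.08 log units; within the scatter) and leaves compound 1 and compound 3 level. No supporting measurement accounts for the difference between compound 2 and compound 3.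

No pair shown separates the point of attachment from the set of alkyl chains, and a 2-butyl-1-methyl-1H-imidazol-5-yl group would test the attachment point with the chains held the same. Also open, as far as these compounds go, is how this position would respond to a ring carrying an amine or a carboxylic acid, or to a chain longer than butyl.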